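A few compounds are considered here, and "the series" means these few. Any claim that something is new, unique, unknown or untested is made for them only; others in the source may bear on it.

Compound 3 `O[C@H](COCCOC[C@@H](O)Cc1cn(-c2cccs2)nn1)Cc1ccc(-c2ccccc2)cc1` gives the highest number of the three measured compounds in a functional assay on SGC-7901 cells (Homo sapiens) for inhibition, read by MTT assay, with a stated time of 72 h (a higher number here means a weaker inhibitor of growth, a lower number a stronger inhibitor of growth), namely 33400 nM; compound 1 `N#Cc1ccc(Cn2cc(C[C@H](O)COCCOC[C@@H](O)Cc3ccc(-c4ccccc4)cc3)nn2)cc1` gives 7700 nM and compound 2 `CC1=C(CCCCCCCCCCn2cc(C[C@H](O)COCCOC[C@@H](O)Cc3ccc(-c4ccccc4)cc3)nn2)C(=O)c2ccccc2C1=O` gives 390 nM. Among the measured compounds shown here, the only measured step on the aromatic nitrogen is a 4.3-fold higher number from compound 1 to compound 3 (0.64 log units; beyond the scatter). Compound 4 `O=C1COc2ccc(-n3cc(C[C@H](O)COCCOC[C@@H](O)Cc4ccc(-c5ccccc5)cc4)nn3)cc2N1` carries a group of 11 heavy atoms (8 carbon, 1 nitrogen, 2 oxygen; one six-membered non-aromatic ring with 2 hetero atoms, one six-membered aromatic ring of carbon only) in place of a group of 5 heavy atoms (4 carbon, 1 sulfur; one five-membered aromatic ring with 1 hetero atom), on an aromatic nitrogen. The measured step moved the number beyond the scatter when 4-cyanobenzyl was exchanged for thiophen-2-yl, and compound 2 with its own substituent on that nitrogen sits far lower still, so a modest move toward a lower number is expected here, of size a 4.8-fold lower number from compound 3 to compound 4 (0.68 log units; beyond the scatter). Compound 4 is therefore estimated to give 7000 nM in this assay, with a range from 1800 nM to 28000 nM.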

Compound 4, concentration for 50% growth inhibition: 15200 nM
Beside the measured number, compound 4's estimate is 2.2-fold (0.34 log units) below it, and the stated range covers the measured number.
By their numbers in this assay, from the lowest: compound 2; then compounds 1 and 4 (each within the scatter of the next); then compound 3.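

On the aromatic nitrogen of the shared core, the group of 11 heavy atoms in place of thiophen-2-yl gives a 2.2-fold lower number from compound 3 to compound 4 (0.34 log units; beyond the scatter) in this assay, so a larger ring-bearing substituent on this nitrogen recovers part of what thiophen-2-yl lost. The same group in place of 4-cyanobenzyl gives a 2.0-fold higher number from compound 1 to compound 4 (0.30 log units; within the scatter), so these two substituents are not separated in this assay, although neither compound 1 nor compound 4 reaches the low number of compound 2. The compounds shown leave open whether a plain alkyl chain, or an amine at the end of such a chain, on this nitrogen would give a number as low as that of compound 2. Nothing available here accounts for these differences.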